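The compounds below may be only part of what the source reports. "The series", "measured", "known", "first", "only" and "open" are said of these compounds alone.

Measured so far:
compound 1, `COc1ccc(CNC(=O)N2C(=O)c3ccccc3S2(=O)=O)cc1`: 0.187 h
compound 2, `O=C(NCc1ccccc1C(F)(F)F)N1C(=O)c2ccccc2S1(=O)=O`: 0.187 h

In a physicochemical assay for pharmacokinetics (on this read-out higher numbers stand for a longer-lived compound and lower numbers for a shorter-lived compound), compound 1 gives 0.187 h, and compound 2 gives 0.187 h, level with compound 1 within the usual scatter. Compound 3 is `O=C(NCc1ccccc1)N1C(=O)c2ccccc2S1(=O)=O` and has not yet been measured. Its difference from compound 2 is hydrogen in place of trifluoromethyl on an aromatic carbon. For the measured compounds named here, no measured pair shows this particular change, so there is no step to anchor on; what is known is only that compound 1 and compound 2, which differ in structure, stand level. For compound 3 a step of a 1.0-fold higher number from compound 2 to compound 3 (0.01 log units; within the scatter) is expected, nothing beyond the scatter. The estimate for compound 3 in this assay is 0.19 h, with a range from 0.09 h to 0.4 h.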

Compound 3, half-life: 1.02 h
The estimate for compound 3 lay 5.4-fold (0.73 log units) below the measured number, outside the stated range (above it).
By their numbers in this assay, from the lowest: compounds 1 and 2 (each within the scatter of the next); then compound 3.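

In this assay, hydrogen in place of trifluoromethyl on an aromatic carbon gives a 5.5-fold higher number from compound 2 to compound 3 (0.74 log units; beyond the scatter), so what this ring carbon carries clearly matters. Hydrogen in place of methoxy gives a 5.5-fold higher number from compound 1 to compound 3 (0.74 log units; beyond the scatter), so both substituted compounds shown lie below the unsubstituted compound 3. No measurement here explains why the number rises. From the compounds shown here alone, it remains open whether only hydrogen gives the higher number, or whether a fluorine atom, a methyl group or an amine on the ring would keep it.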